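The source may hold more compounds than are shown below. What is called first, only, known or untested is meant among the compounds shown, and "the series" means these compounds.

Compound 1 `CO[C@@H]1CC=C2NN(c3cc4ccccc4[nH]3)C(=O)C[C@]2(c2ccccc2)O1` gives 9100 nM in a functional assay on SK-N-SH cells (Homo sapiens) for inhibition, read by sulforhodamine B assay, with a stated time of 48 h; a higher number here means a weaker inhibitor, a lower number a stronger inhibitor.
Compound 2 `COc1cc(OC)cc(N2NC3=CC[C@@H](OC)O[C@@]3(c3ccccc3)CC2=O)c1` gives 19500 nM in this assay.
Compound 3 `COc1cc(OC)cc(N2NC3=CC[C@@H](OC)O[C@@]3(c3ccncc3)CC2=O)c1` gives 6400 nM in this assay.

Compound 2 and compound 3 share one core and differ in a single place, (pyridin-4-yl in place of phenyl on a saturated ring carbon). That change produced a 3.0-fold lower number from compound 2 to compound 3 (0.48 log units; beyond the scatter). Compound 1 is built on a different core, and the difference between the two cores is not broken down here. In this assay the value of compound 1 lies within the scatter of that of compound 3, while it stands beyond the scatter below that of compound 2.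

Compound 4 `CO[C@@H]1CC=C2NN(c3cc4ccccc4[nH]3)C(=O)C[C@]2(c2ccncc2)O1` has not yet been measured. It differs from compound 1 by pyridin-4-yl in place of phenyl on a saturated ring carbon. Within the data shown here, this is the same kind of change as the one from compound 2 to compound 3, but not the same: in compound 1 the group sits on a saturated ring carbon of a six-membered non-aromatic ring with 1 oxygen, next to the ring oxygen, next to the ring atom that bears a fused ring and two ring bonds from the ring atom that bears a methoxy group, whereas in compound 2 it sits on a saturated ring carbon of a six-membered non-aromatic ring with 2 nitrogen, two ring bonds and three ring bonds from the ring nitrogens and three ring bonds from the ring atom that bears a large group.

Among the measured compounds shown here, the step from compound 1 to compound 4 in this assay is expected to be a 3.0-fold lower number from compound 1 to compound 4 (0.48 log units; beyond the scatter), resting on the single measured instance of this kind of change, a 3.0-fold lower number from compound 2 to compound 3 (0.48 log units; beyond the scatter), with a wider range given the different surroundings. Compound 4 is therefore estimated at 3000 nM, between 1500 nM and 7000 nM.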

Compound 4, half-maximal inhibitory concentration: 3900 nM
Compound 4: the middle estimate sits 1.3-fold (0.11 log units) below what was measured; the range from low to high includes it.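

In this assay, placing pyridin-4-yl instead of phenyl on the saturated ring carbon of the core of compound 1 gave a 2.3-fold lower number from compound 1 to compound 4 (0.37 log units; beyond the scatter), and this step can be set directly beside the earlier one on the other core: the same change on two cores in this assay, a 3.0-fold lower number (0.48 log units; beyond the scatter) from compound 2 to compound 3 and a 2.3-fold lower number (0.37 log units; beyond the scatter) from compound 1 to compound 4, 1.3-fold (0.12 log units) apart, within the scatter of two such steps. Across these two cores, then, the change carried over in the same direction and, within the scatter, with the same size, so the step measured on one core was a fair guide to the step on the other. Among these compounds, this rests on only two matched pairs in a single cell assay, and it shows neither why the change lowers the number nor that it would do so on a third core or in another assay.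

The compounds shown leave open whether the lower number is particular to pyridin-4-yl or would also appear with another group on that carbon, such as pyridin-3-yl, pyridin-2-yl or a fluorophenyl. They also leave open how the step would behave if the methoxy group on the neighbouring part of the ring system gave way to a hydroxyl or a longer ether such as ethoxy.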